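A few compounds are considered here, and "the series" means these few. Any claim that something is new, unique, unknown or untested is made for them only; others in the source may bear on it.

Measured in a functional assay on DU-145 cells (Homo sapiens) for antiproliferative activity, read by MTT assay; on this read-out higher numbers stand for weaker inhibition and lower numbers for stronger inhibition:
- compound 1 `c1ccc2c(c1)ccn2-c1nc(N2CCNCC2)nc2ccccc12`: 12.5 ug/mL
- compound 2 `c1ccc(N2CCN(c3nc(-n4ccc5ccccc54)c4ccccc4n3)CC2)cc1`: 50 ug/mL

Within the data shown here, compound 2 has the higher number of the two, and compound 1 is its only neighbour. Compound 3 `c1ccc(N2CCN(c3nc(-n4ccc5ccccc54)c4ccccc4n3)CC2)nc1` is not yet measured. It carries pyridin-2-yl in place of phenyl on an amine nitrogen in a ring.

Among the measured compounds shown here, one measured step touches that same nitrogen: a 4.0-fold higher number from compound 1 to compound 2 (0.60 log units; beyond the scatter). This modest step put phenyl in place of hydrogen, whereas the new change swaps one aromatic ring for another. For the measured compounds named here, no measured compound shows what a hetero atom in this ring does, so the direction stays open. No step beyond the scatter is expected in this assay. The expected step is a 1.3-fold lower number from compound 2 to compound 3 (0.10 log units; within the scatter). Compound 3 is estimated at 40 ug/mL, with an expected range of 15 ug/mL to 100 ug/mL.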

Compound 3, half-maximal inhibitory concentration: 50 ug/mL
Compound 3: middle estimate off by 1.3-fold (0.10 log units), on the low side, and the stated range covers the measured number.
By their numbers in this assay, from the lowest: compound 1; then compounds 2 and 3 (each within the scatter of the next).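

In this assay, pyridin-2-yl in place of phenyl on the amine nitrogen in the ring gives no change at the digits printed from compound 2 to compound 3 (within the scatter), so the hetero atom and the hydrogen-bond acceptor that enter with this aromatic ring do not move the number beyond the scatter. Measured against the free ring amine, pyridin-2-yl gives a 4.0-fold higher number from compound 1 to compound 3 (0.60 log units; beyond the scatter), the same size as the phenyl step, a 4.0-fold higher number from compound 1 to compound 2 (0.60 log units; beyond the scatter), so compound 1 remains the stronger inhibitor against either aromatic ring at this position. No measurement on hand explains why the two aromatic rings read alike or why both fall short of the free amine.

From the compounds shown here alone, whether a methyl or a benzyl group on this nitrogen would stay closer to compound 1 remains open. Also open, going by these compounds, is whether a carboxylic acid or an amine on the aromatic ring would shift the number from that of compound 3.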